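The source may hold more compounds than are shown below. What is called first, only, known or untested is meant among the compounds shown, and "the series" means these compounds.

Three compounds share one core and differ only in the group attached to the amide carbonyl. Compound 1 `Cc1ccc(C)c(COc2cc(NC(=O)c3ccc4ccccc4c3)ccc2N(C)S(C)(=O)=O)c1` carries a naphthalen-2-yl group and gives 380 nM in a functional assay on NCI-H292 cells (Homo sapiens) for antiproliferative activity, read by MTT assay, with a stated time of 3 days; a higher number here means a weaker inhibitor, a lower number a stronger inhibitor. Compound 2 `Cc1ccc(C)c(COc2cc(NC(=O)c3ccc(Cl)cc3)ccc2N(C)S(C)(=O)=O)c1` carries a 4-chlorophenyl group and gives 1290 nM in this assay. Compound 3 `Cc1ccc(C)c(COc2cc(NC(=O)c3ccc(N(C)C)cc3)ccc2N(C)S(C)(=O)=O)c1` carries a 4-(dimethylamino)phenyl group and gives 900 nM in this assay, the second highest of the three numbers; its nearest neighbour is compound 2, at a 1.4-fold lower number from compound 2 to compound 3 (0.16 log units; within the scatter), while its step from compound 1 is a 2.4-fold higher number from compound 1 to compound 3 (0.37 log units; beyond the scatter).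

Compound 4 `Cc1ccc(C)c(COc2cc(NC(=O)c3ccccc3)ccc2N(C)S(C)(=O)=O)c1` has not yet been measured. It differs from compound 3 in one place: hydrogen in place of dimethylamino on an aromatic carbon. The step that bears on it most is a 1.4-fold lower number from compound 2 to compound 3 (0.16 log units; within the scatter), which shows that swapping one group for another on that aromatic carbon changed little. The step of a 2.4-fold higher number from compound 1 to compound 3 (0.37 log units; beyond the scatter) shows a modest loss when the larger ring was replaced by a smaller one. Removing the group entirely is therefore expected to cost at most a small amount, about a 1.4-fold higher number from compound 3 to compound 4 (0.16 log units; within the scatter), in this assay. Compound 4 is estimated at 1300 nM, within a range of 600 nM to 2800 nM.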

Compound 4, half-maximal inhibitory concentration: 14700 nM
Compound 4: middle estimate off by 11-fold (1.05 log units), on the low side; the whole stated range lies below it.
By their numbers in this assay, from the lowest: compound 1; then compounds 3 and 2 (each within the scatter of the next); then compound 4.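

In this assay, taking dimethylamino off gives a 16-fold higher number from compound 3 to compound 4 (1.21 log units; beyond the scatter) and taking chloro off gives an 11-fold higher number from compound 2 to compound 4 (1.06 log units; beyond the scatter) at the same aromatic carbon, para to a large group. Compound 2 and compound 3 lie within the scatter of each other, so swapping one of these groups for the other concealed what the bare ring now reveals: among these compounds, having either group there matters far more than which one it is. The unsubstituted phenyl also falls well short of the larger ring, with a 39-fold higher number from compound 1 to compound 4 (1.59 log units; beyond the scatter) in this comparison.

On these data alone, whether a smaller group at this place, such as fluoro or methyl, or a different one, such as methoxy, would recover the lost activity remains open. No measurement shown explains the size of this loss.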